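Regiochemistry of the Trifluoromethylphenyl Hydrazone Arm

The source may hold more compounds than are shown below. What is called first, only, known or untested is meant among the compounds shown, and "the series" means these compounds.

Compound 3 `CN(C(=O)NC(=O)c1c(F)cccc1F)c1nc(C(F)(F)F)c(C(=O)N/N=C/c2ccc(C(F)(F)F)cc2)s1` gives the highest number of the three measured compounds in a functional assay on MCF7 cells (Homo sapiens) for inhibition, read by MTT assay, with a stated time of 72 h (on this read-out lower numbers stand for stronger inhibition and higher numbers for weaker inhibition), at 35.3 ug/mL. Among the compounds with values here, compound 1 `CN(C(=O)NC(=O)c1cccc(C(F)(F)F)c1)c1nc(C(F)(F)F)c(C(=O)N/N=C/c2ccccc2C(F)(F)F)s1` and compound 2 `CN(C(=O)NC(=O)c1cccc([N+](=O)[O-])c1)c1nc(C(F)(F)F)c(C(=O)N/N=C/c2ccccc2C(F)(F)F)s1` differ from each other only in the acyl part, and the one measured step there, a 1.6-fold lower number from compound 1 to compound 2 (0.21 log units; within the scatter), does not touch the site now varied. Compound 4 `CN(C(=O)NC(=O)c1c(F)cccc1F)c1nc(C(F)(F)F)c(C(=O)N/N=C/c2ccccc2C(F)(F)F)s1` differs from compound 3 by 2-(trifluoromethyl)phenyl in place of 4-(trifluoromethyl)phenyl on a carbon with a double bond to nitrogen. Within the data shown here, no measured step covers this change directly. Compound 1 gives 7.69 ug/mL and compound 2 gives 4.73 ug/mL, both carrying 2-(trifluoromethyl)phenyl on the carbon with a double bond to nitrogen, against compound 3 at 35.3 ug/mL; they also differ elsewhere, so a modest step toward lower numbers is expected, a 2.9-fold lower number from compound 3 to compound 4 (0.47 log units; beyond the scatter), with wide uncertainty. Compound 4 is estimated at 12 ug/mL, range 5 ug/mL to 30 ug/mL.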

Compound 4, half-maximal inhibitory concentration: 20.4 ug/mL
For compound 4 the middle estimate is 1.7-fold (0.23 log units) below the measured one, within the range that was stated.
By their numbers in this assay, from the lowest: compounds 2 and 1 (each within the scatter of the next); then compounds 4 and 3 (each within the scatter of the next).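

In this assay the swap from 4-(trifluoromethyl)phenyl to 2-(trifluoromethyl)phenyl gives a 1.7-fold lower number from compound 3 to compound 4 (0.24 log units; within the scatter) and so does not separate this pair. With 2-(trifluoromethyl)phenyl held fixed, the acyl part does move the number: 2,6-difluorophenyl gives a 4.3-fold higher number from compound 2 to compound 4 (0.63 log units; beyond the scatter) and a 2.7-fold higher number from compound 1 to compound 4 (0.42 log units; beyond the scatter) as modest steps. No available evidence bears on these results.

Open, on these data alone, is whether an amine or a carboxylic acid in place of trifluoromethyl on this aromatic ring would give a step beyond the scatter. Also open, as far as these compounds go, is whether the swap behaves alike with other acyl parts.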